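This account rests on a few compounds, and the source may have more. Where it says the series, first, only, none or still open, it means among the compounds named here.

Compound 1 `CCOC(=O)N1CCC(=NNC(=O)c2ccc([N+](=O)[O-])cc2)CC1`: 10900 nM
Compound 2 `O=C(NN=C1CC(c2ccccc2)NC(c2ccccc2)C1)c1ccccc1`: 238000 nM

Both values come from a functional assay, read by spectrophotometry; on this read-out lower numbers stand for stronger inhibition and higher numbers for weaker inhibition. Of the two, compound 2 has the higher number and is the weaker inhibitor, and its gap to compound 1 lies beyond the scatter. The two compounds differ in several places, so this gap cannot be pinned on any single group.

Compound 3 `O=C(NN=C1CC(c2ccccc2)NC(c2ccccc2)C1)c1ccc(F)cc1C(F)(F)F` keeps the core of compound 2 and changes one place: 4-fluoro-2-(trifluoromethyl)phenyl in place of phenyl on a carbonyl carbon. Here, 4-fluoro-2-(trifluoromethyl)phenyl stands in place of phenyl on a carbonyl carbon. Going by the values given here, no measured pair shows a single change like this, so any forecast is loose.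

Compound 2 already sits high at 238000 nM, so a modest move to lower numbers in this assay is expected, though a result within the scatter remains possible. The expected step is a 2.4-fold lower number from compound 2 to compound 3 (0.38 log units; beyond the scatter). For compound 3 the estimated value is 100000 nM, with an expected range from 25000 nM to 300000 nM.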

Compound 3, half-maximal inhibitory concentration: 88500 nM
Beside the measured number, compound 3's estimate is 1.1-fold (0.05 log units) above it, and the stated range covers the measured number.
By their numbers in this assay, from the lowest: compound 1; then compound 3; then compound 2.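

Going by these compounds alone, putting 4-fluoro-2-(trifluoromethyl)phenyl in place of phenyl on a carbonyl carbon gives, in this assay, a 2.7-fold lower number from compound 2 to compound 3 (0.43 log units; beyond the scatter), and this is the only step here that changes a single place. It shows that this position is sensitive to the group it carries, with a change beyond the scatter. It also shows that the larger group is accepted there and gives modestly stronger inhibition, although the inhibition remains weaker than that of compound 1, a compound that differs in several places. No measurement is available to explain this shift.

The fluorine and the trifluoromethyl group enter together, so the compounds shown leave open whether either one alone would give this step. They also leave open how a phenyl carrying an amine or a carboxylic acid would behave at this position.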